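The source may hold more compounds than are shown below. What is called first, only, known or untested is meant among the compounds shown, and "the series" means these compounds.

Compound 1 `COc1ccc(NS(=O)(=O)/C=C/c2ccccc2OC)cc1`: 5000 nM
Compound 2 `COc1ccc(NS(=O)(=O)/C=C/c2c(OC)cccc2OC)cc1`: 5000 nM

Both compounds were tested in a functional assay on K562 cells (Homo sapiens) for cytotoxicity, read by trypan blue exclusion, with a stated time of 96 h (on this read-out higher numbers stand for weaker inhibition and lower numbers for stronger inhibition), where compound 2, at 5000 nM, stands level with compound 1. Compound 3 `COc1ccc(NS(=O)(=O)/C=C/c2c(OC)cc(O)cc2OC)cc1` differs from compound 2 by one change: hydroxy in place of hydrogen on an aromatic carbon. Among the compounds with values here, only one measured step bears on this, and it involves methoxy rather than hydroxy: no change at the digits printed from compound 1 to compound 2 (within the scatter). That flat step sets no firm size for the new change, so only a modest gain in inhibition is expected, and no change beyond the scatter remains possible. The expected step is a 2.5-fold lower number from compound 2 to compound 3 (0.40 log units; beyond the scatter). For compound 3 the estimated value is 2000 nM, with an expected range of 250 nM to 6000 nM.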

Compound 3, half-maximal inhibitory concentration: 10000 nM
Beside the measured number, compound 3's estimate is 5.0-fold (0.70 log units) below it; measured number outside the range, above it.
By their numbers in this assay, from the lowest: compounds 1, 2 and 3 (each within the scatter of the next).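

In this assay, hydroxy in place of hydrogen on the aromatic carbon that lies meta to two methoxy groups and para to a large group gives a 2.0-fold higher number from compound 2 to compound 3 (0.30 log units; within the scatter), so this position accepts a hydroxy group with no step beyond the scatter. Like the earlier methoxy change, this change brings no measurable gain in inhibition. No measurement available here accounts for this result. As far as these compounds go, whether an amine, a carboxylic acid or a longer alkoxy chain at this same place would move the number beyond the scatter remains open.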